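This account rests on a few compounds, and the source may have more. Where it says the series, first, only, none or still open, it means among the compounds named here.

Series notes. Among the compounds with values here, in a functional assay on KB cells (Homo sapiens) for antiproliferative activity, read by sulforhodamine B assay, with a stated time of 3 days (a lower number here means a stronger inhibitor of growth, a higher number a weaker inhibitor of growth), compound 1 `O=C(NCCO)c1cccc(Nc2ncc(F)c(Nc3ccc(F)cc3)n2)c1` gives 12400 nM, the highest of the two numbers so far; compound 2 `COc1ccc(N2CCN(C)CC2)cc1Nc1ncc(F)c(Nc2ccc(F)cc2)n1` gives 960 nM, a lower number by a margin beyond the scatter. Within the data shown here, no pair measured so far differs in a single place, so no measured step guides the next change. Compound 3 `O=C(Nc1cccc(Nc2ncc(F)c(Nc3ccc(F)cc3)n2)c1)c1ccccc1` differs from compound 1 by benzamido in place of (2-hydroxyethyl)carbamoyl on an aromatic carbon. With nothing measured on this change, the expected step of a 1.4-fold lower number from compound 1 to compound 3 (0.14 log units; within the scatter) is taken as none beyond the scatter, direction open. Compound 3 is therefore estimated at 9000 nM in this assay, with a range from 2500 nM to 30000 nM.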

Compound 3, concentration for 50% growth inhibition: > 10000 nM
Compound 3 was reported as a limit (the forecaster's own chance of this, stated with the estimate: 10%); middle value at least 1.1-fold (0.04 log units) from the limit.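

In this assay compound 3 gives > 10000 nM as a limit and not a number. Within the data shown here, no step from compound 1 to compound 3 can be read: the limit of > 10000 nM in this assay, at which 1 of the 3 values shown sits. The compounds shown leave open how far benzamido in place of (2-hydroxyethyl)carbamoyl moves growth inhibition, and in which direction.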